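Trifluoromethyl Replaced by Hydroxy on Two Cores

The source may report more compounds than this note shows. Statements on the series, on what has been measured and on what is new or still open speak of the compounds shown alone.

Compound 1 `O=C(Nc1ccc(C(F)(F)F)cc1)C1CCc2ccccc2N1`: 25000 nM
Compound 2 `CCCCCCCCC(=O)N1c2ccccc2CCC1C(=O)Nc1ccccc1C(F)(F)F`: 8330 nM
Compound 3 `O=C(Nc1ccc(O)cc1)C1CCc2ccccc2N1`: > 100000 nM

In a functional assay on ACHN cells (Homo sapiens) for cytotoxicity, read by sulforhodamine B assay, with a stated time of 72 h (on this read-out higher numbers stand for weaker inhibition of growth and lower numbers for stronger inhibition of growth), compound 1 gives 25000 nM. Compound 3 gives only > 100000 nM, which is a limit of the assay rather than a number. The change hydroxy in place of trifluoromethyl on an aromatic carbon therefore brought an at least 4.0-fold higher number from compound 1 to compound 3 (0.60 log units; beyond the scatter). Compound 2 gives 8330 nM, the lowest of the two numbers here; how its core differs from the core of compound 1 is not broken down here. Compound 4 `CCCCCCCCC(=O)N1c2ccccc2CCC1C(=O)Nc1ccccc1O` carries the same kind of change, (hydroxy in place of trifluoromethyl on an aromatic carbon), with the hydroxy now ortho to a large group rather than para to a large group. Resting on the step of an at least 4.0-fold higher number from compound 1 to compound 3 (0.60 log units; beyond the scatter), compound 4 is expected to show a 4.2-fold higher number from compound 2 to compound 4 (0.62 log units; beyond the scatter). Compound 4 is estimated at 35000 nM, between 12000 nM and 100000 nM.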

Compound 4, concentration for 50% growth inhibition: 65000 nM
Compound 4: the middle estimate sits 1.9-fold (0.27 log units) below what was measured, within the range that was stated.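

In this assay, hydroxy in place of trifluoromethyl on an aromatic carbon brought a 7.8-fold higher number from compound 2 to compound 4 (0.89 log units; beyond the scatter), so the change moved the number in the same direction on both cores. How far the size of the step carries from one core to the other stays unsettled: the same change on two cores in this assay, an at least 4.0-fold higher number (0.60 log units; beyond the scatter) from compound 1 to compound 3 and a 7.8-fold higher number (0.89 log units; beyond the scatter) from compound 2 to compound 4; the limit leaves it open whether they differ. The value of compound 3 is a limit and not a number: the limit of > 100000 nM in this assay, at which 1 of the 4 values shown sits.

The compounds shown leave open what an amine or a carboxylic acid would give in place of trifluoromethyl on either core. Within the data shown here, they also leave open whether the step would hold with a longer chain than the one in compound 2 and compound 4.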